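A few compounds are considered here, and "the series" means these few. Any claim that something is new, unique, unknown or untested is made for them only; others in the source may bear on it.

Three compounds share one core. Compound 1 `O=c1cc(-c2ccccc2)oc2cc(OCCCCNc3nc4ccccc4s3)cc(O)c12` gives 8.57 ug/mL in a physicochemical assay, read by spectrophotometry, with a stated time of 10 min; on this read-out higher numbers stand for weaker inhibition and lower numbers for stronger inhibition. Compound 2 `Cc1ccc2nc(NCCCCOc3cc(O)c4c(=O)cc(-c5ccccc5)oc4c3)sc2c1` gives 8.79 ug/mL in this assay, and compound 3 `O=C(O)c1ccc2nc(NCCCCOc3cc(O)c4c(=O)cc(-c5ccccc5)oc4c3)sc2c1` gives 6.74 ug/mL in this assay. Compound 2 sits alongside the other two: the step of a 1.0-fold higher number from compound 1 to compound 2 (0.01 log units; within the scatter) and the step of a 1.3-fold lower number from compound 2 to compound 3 (0.12 log units; within the scatter) both stay within the scatter, as does the step of a 1.3-fold lower number from compound 1 to compound 3 (0.10 log units; within the scatter), so the three numbers cannot be told apart.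

Compound 4 `O=c1cc(-c2ccccc2)oc2cc(OCCCCNNc3nc4ccccc4s3)cc(O)c12` differs from compound 2 by (1,3-benzothiazol-2-yl)amino in place of 6-methyl-1,3-benzothiazol-2-yl on an amine nitrogen. The same difference, cut one bond further out, reads (6-methyl-1,3-benzothiazol-2-yl)amino to ((1,3-benzothiazol-2-yl)amino)amino; the place is an amine nitrogen whose other neighbour is a saturated chain carbon.

Going by the values given here, of the measured steps, only the step of a 1.0-fold higher number from compound 1 to compound 2 (0.01 log units; within the scatter) touches the methyl that leaves, and it lies within the scatter; no measured step tries the extra amino group in the chain. The expected step is therefore a 1.0-fold lower number from compound 2 to compound 4 (0.01 log units; within the scatter), with a wide margin for the untested change. Compound 4 is estimated at 8.5 ug/mL, between 4 ug/mL and 18 ug/mL.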

Compound 4, half-maximal inhibitory concentration: 8.73 ug/mL
Compound 4: middle estimate off by 1.0-fold (0.01 log units), on the low side, and the stated range covers the measured number.
By their numbers in this assay, from the lowest: compounds 3, 1, 4 and 2 (each within the scatter of the next).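

Going by these compounds alone, compound 4 carries the first change in the chain itself rather than on the benzothiazole ring, and in this assay adding this amino group gives a 1.0-fold higher number from compound 1 to compound 4 (0.01 log units; within the scatter) and so no readable shift. The steps of a 1.0-fold lower number from compound 2 to compound 4 (0.00 log units; within the scatter) and a 1.3-fold higher number from compound 3 to compound 4 (0.11 log units; within the scatter) also stay within the scatter, so the four compounds cannot be told apart and this amine nitrogen accepts the added amino group without a detectable effect on the number. No measurement in hand offers a reason for this flat result.

As far as these compounds go, it remains open whether a longer chain, an amide or an ether oxygen at this place in the chain would leave the number just as level. Also open, from the compounds shown here alone, is whether a larger group, such as a piperazine, would move the number beyond the scatter.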